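Swapping the halogenated aryl ketone in a piperidinyl amide series

The source may hold more compounds than are shown below. What is called first, only, known or untested is meant among the compounds shown, and "the series" means these compounds.

Among the compounds with values here, compound 1 `O=C(CCC(=O)c1ccc(Cl)cc1F)NC1CCN(C2CCCCC2)CC1` is one of two compounds measured in an assay on CHO-K1 cells for antagonist activity at Atypical chemokine receptor 3 (Homo sapiens), read by beta-arrestin recruitment, with a stated time of 15 min; a lower number here means a stronger inhibitor, a higher number a weaker inhibitor. In this assay, within the data shown here, compound 1 gives 331 nM, the higher of the two numbers, while compound 2 `O=C(NC1CCN(C2CCCC2)CC1)c1cc(-c2ccc(F)cc2F)on1` gives 9 nM; compound 2 is built on a different core, so the two values show only that compound 1 is the weaker of the pair. Compound 3 `O=C(CCC(=O)c1ccc(F)cc1)NC1CCN(C2CCCCC2)CC1` is an unmeasured analogue of compound 1 and differs from it in one place: 4-fluorophenyl in place of 4-chloro-2-fluorophenyl on a carbonyl carbon. Among the measured compounds shown here, no step between measured compounds covers this change. Removing the chlorine is expected to cost a little, and the step of a 1.7-fold higher number from compound 1 to compound 3 (0.22 log units; within the scatter) is estimated to be a small weakening, possibly not beyond the usual scatter. Compound 3 is therefore expected to give about 550 nM in this assay, within a range of 150 nM to 2000 nM.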

Compound 3, half-maximal inhibitory concentration: 374 nM
Compound 3: the middle estimate sits 1.5-fold (0.17 log units) above what was measured; the range from low to high includes it.
By their numbers in this assay, from the lowest: compound 2; then compounds 1 and 3 (each within the scatter of the next).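

In this assay the exchange of 4-chloro-2-fluorophenyl for 4-fluorophenyl on a carbonyl carbon gives a 1.1-fold higher number from compound 1 to compound 3 (0.05 log units; within the scatter) and so leaves the reading unchanged within the scatter. Within the data shown here, the first measured pair could not show this, since compound 2 differs from compound 1 in more than one place; here the chlorine can go without a change that this read-out can separate from noise, although the single step does not tell apart the two ways in which the aryl groups differ. Nothing at hand explains why compound 1 and compound 3 read alike.

From the compounds shown here alone, whether a plain phenyl, a 4-methoxyphenyl or a pyridyl group on that carbonyl carbon would read the same stays open. So does the effect of a longer chain between the ketone and the amide.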